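Cytotoxicity series: bromo to benzyloxy swap

The source may hold more compounds than are shown below. What is called first, only, known or untested is meant among the compounds shown, and "the series" means these compounds.

The series is followed in a functional assay on MDA-MB-231 cells (Homo sapiens) for cytotoxicity, read by MTT assay, with a stated time of 24 h; a higher number here means a weaker inhibitor, a lower number a stronger inhibitor. Compound 1, `Cc1cc(O)c(C(=O)/C=C/c2cccc(Cl)c2)c(-c2ccccc2)c1C(=O)/C=C/c1cccc(Cl)c1`, gives 4670 nM in this assay. Compound 2, `COc1ccc(/C=C/C(=O)c2c(C)cc(O)c(C(=O)/C=C/c3ccc(OC)cc3)c2-c2ccc(Br)cc2)cc1`, is reported in this assay as "not active" (no number reported), without a numerical value, so compound 2 has no number to set beside compound 1; on the figures shown, compound 2 stands only as a compound for which no half-maximal inhibitory concentration was reached, while compound 1 carries a measured number. Among the measured compounds shown here, no step between measured compounds is available here.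

Compound 3, `COc1ccc(/C=C/C(=O)c2c(C)cc(O)c(C(=O)/C=C/c3ccc(OC)cc3)c2-c2ccc(OCc3ccccc3)cc2)cc1`, is the compound still to be measured. It differs from compound 2 in one place: benzyloxy in place of bromo on an aromatic carbon. For the measured compounds named here, no measured pair shows what this change does in this assay, so no step size exists for it, and its direction cannot be read from the data. Given that compound 2 gives "not active" (no number reported), compound 3 is expected to remain a weak inhibitor, with a real chance that this assay again reports no number. The estimate for compound 3 in this assay is 30000 nM, within a range from 6000 nM to 150000 nM.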

Compound 3, half-maximal inhibitory concentration: 12000 nM
Compound 3: middle estimate off by 2.5-fold (0.40 log units), on the high side, and the stated range covers the measured number.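

No step can be read from compound 2 to compound 3 in this assay: compound 2 carries "not active" without a number, while compound 3 gives 12000 nM. The compounds shown leave open how large the effect of benzyloxy in place of bromo is in this series. Nothing available bears on a cause for this result.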